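From a chloropyridine to a trifluoromethylphenyl group

The source may report more compounds than this note shows. Statements on the series, on what has been measured and on what is new or still open speak of the compounds shown alone.

Compound 3 `CC(C)(C)CC[C@H](c1ccc(C(=O)NCc2nn[nH]n2)cc1)N1C(=O)C(c2cncc(Cl)c2)=N[C@]12CC[C@@H](C(C)(C)C)CC2` gives 84 nM in an assay on membranes from liver for displacement of a labelled ligand from Glucagon receptor (Mus musculus), read by scintillation counting, with a stated time of 60 min (on this read-out higher numbers stand for weaker inhibition and lower numbers for stronger inhibition), the lowest of the three numbers recorded in that assay and far apart from the other two. Compound 1 `CC(C)(C)[C@H]1CC[C@]2(CC1)N=C(c1cccc(C(F)(F)F)c1)C(=O)N2Cc1ccc(C(=O)NCCC(=O)O)cc1` gives 10000 nM and compound 2 `CC(C)(C)[C@H]1CC[C@]2(CC1)N=C(c1ccc(C(F)(F)F)cc1)C(=O)N2Cc1ccc(C(=O)NCCC(=O)O)cc1` gives 9600 nM; both carry a trifluoromethylphenyl group on the carbon with a double bond to nitrogen but differ from compound 3 in other parts of the molecule as well, so their numbers show only that this class of aryl group can sit there. Among the measured compounds shown here, the one measured single change, a 1.0-fold lower number from compound 1 to compound 2 (0.02 log units; within the scatter), moves the trifluoromethyl group around its phenyl ring and changes almost nothing.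

Compound 4 `CC(C)(C)CC[C@H](c1ccc(C(=O)NCc2nn[nH]n2)cc1)N1C(=O)C(c2cccc(C(F)(F)F)c2)=N[C@]12CC[C@@H](C(C)(C)C)CC2` is compound 3 with one change: 3-(trifluoromethyl)phenyl in place of 5-chloropyridin-3-yl on a carbon with a double bond to nitrogen. For the measured compounds named here, no measured step covers exactly this exchange. Compounds 1 and 2 suggest the trifluoromethylphenyl group is not ruled out at this position, while the much lower number of compound 3 comes with the chloropyridine. A modest loss of potency is therefore expected, with a 2.1-fold higher number from compound 3 to compound 4 (0.33 log units; beyond the scatter) as the estimated step. For compound 4 the expected value in this assay is 180 nM, estimated to lie between 50 nM and 700 nM.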

Compound 4, half-maximal inhibitory concentration: 140 nM
For compound 4 the middle estimate is 1.3-fold (0.11 log units) above the measured one; measured number inside the range.
By their numbers in this assay, from the lowest: compounds 3 and 4 (each within the scatter of the next); then compounds 2 and 1 (each within the scatter of the next).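

In this assay, putting 3-(trifluoromethyl)phenyl in place of 5-chloropyridin-3-yl gives a 1.7-fold higher number from compound 3 to compound 4 (0.22 log units; within the scatter), so on this shared core the two groups cannot be told apart at this position. Among the compounds shown here, this is the first comparison of the two groups with the rest of the molecule held the same, and it shows that the entering ring, made of carbon only and with no hydrogen-bond acceptor, gives a number within the scatter of that given by the leaving ring, which has a ring nitrogen, a chlorine and one hydrogen-bond acceptor. No measured evidence is available to explain why the exchange makes so little difference.

These two compounds alone do not show how far this tolerance extends, for example to an unsubstituted phenyl ring, or to a pyridine ring carrying an amine or a carboxylic acid. For the compounds shown here, it also remains open whether 4-(trifluoromethyl)phenyl on the core of compound 3 would match the 3-(trifluoromethyl)phenyl group of compound 4, since the only step between those two groups, a 1.0-fold lower number from compound 1 to compound 2 (0.02 log units; within the scatter), was read on a different core.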